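Ethoxy in Place of Chloro: An Expected Cytotoxicity Value

The source may hold more compounds than are shown below. What is called first, only, known or untested is meant among the compounds shown, and "the series" means these compounds.

Compound 3 `O=C(Nc1nc(-c2cccc(Cl)c2)cs1)c1ccc([N+](=O)[O-])o1` gives 43700 nM in an ADME assay on Vero cells (Chlorocebus sabaeus) for cytotoxicity, read by MTT assay, with a stated time of 72 h (on this read-out higher numbers stand for weaker inhibition and lower numbers for stronger inhibition), the second highest of the three numbers measured. Compound 1 `O=C(Nc1nc(-c2ccccc2)cs1)c1ccc([N+](=O)[O-])o1` gives 41700 nM in this assay, and compound 2 `COc1cccc(-c2csc(NC(=O)c3ccc([N+](=O)[O-])o3)n2)c1` gives 58700 nM. Compound 4 `CCOc1cccc(-c2csc(NC(=O)c3ccc([N+](=O)[O-])o3)n2)c1` differs from compound 3 by ethoxy in place of chloro on an aromatic carbon. The measured steps that bear on this exchange are all small: a 1.4-fold higher number from compound 1 to compound 2 (0.15 log units; within the scatter), a 1.3-fold lower number from compound 2 to compound 3 (0.13 log units; within the scatter) and a 1.0-fold higher number from compound 1 to compound 3 (0.02 log units; within the scatter). Since none of these substituent exchanges on an aromatic carbon moved the read-out beyond the scatter, the estimated step is a 1.1-fold higher number from compound 3 to compound 4 (0.06 log units; within the scatter), with no change beyond the scatter expected. Compound 4 is therefore expected to give about 50000 nM in this assay, with an estimated range from 25000 nM to 100000 nM.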

Compound 4, half-maximal inhibitory concentration: > 90000 nM
Compound 4: only a limit was reported (the forecaster's own chance of this, stated with the estimate: 10%); middle value at least 1.8-fold (0.25 log units) from the limit.
By their numbers in this assay, from the lowest: compounds 1, 3 and 2 (each within the scatter of the next). At a limit, above all of these: compound 4.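

Compound 4 is reported in (this assay) only as a limit (> 90000 nM). Going by these compounds alone, on this aromatic carbon, ethoxy is the first group to carry the read-out beyond the scatter, both in place of chloro (an at least 2.0-fold higher number from compound 3 to compound 4 (0.31 log units; beyond the scatter)) and in place of hydrogen (an at least 2.1-fold higher number from compound 1 to compound 4 (0.33 log units; beyond the scatter)). Against methoxy, the floor of the step stays within the scatter (an at least 1.5-fold higher number from compound 2 to compound 4 (0.18 log units; that floor lies within the scatter)), so the added methyl is not shown to count by itself. Going by these compounds, the true value of compound 4 remains open, as does whether a longer chain such as propoxy or an amine on this carbon would give a similar number.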